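From 4-methylphenyl to 3-nitrophenyl: notes on compound 3

The source may hold more compounds than are shown below. What is called first, only, known or untested is meant among the compounds shown, and "the series" means these compounds.

In a functional assay on NCI-H460 cells (Homo sapiens) for cytotoxicity, read by sulforhodamine B assay (a lower number here means a stronger inhibitor of growth, a higher number a weaker inhibitor of growth), compound 1 `CC1=CC[C@@H]([C@@](C)(O)CCCC(C)(C)NC(=S)N/N=C\c2ccc(C)cc2)CC1` gives 10100 nM and compound 2 `CC1=CC[C@@H]([C@@](C)(O)CCCC(C)(C)NC(=S)N/N=C\c2ccc(N(C)C)cc2)CC1` gives 19600 nM, so compound 1 stands level with compound 2 within the scatter. Compound 3 `CC1=CC[C@@H]([C@@](C)(O)CCCC(C)(C)NC(=S)N/N=C\c2cccc([N+](=O)[O-])c2)CC1` brings (3-nitrophenyl in place of 4-methylphenyl on a carbon with a double bond to nitrogen). Among the compounds with values here, the only measured step bearing on this change is a 1.9-fold higher number from compound 1 to compound 2 (0.29 log units; within the scatter), with dimethylamino in place of methyl on an aromatic carbon. Within the data shown here, no measured compound carries a nitro group, so this guide is weak. The expected step is a 1.2-fold higher number from compound 1 to compound 3 (0.07 log units; within the scatter), with no change beyond the scatter expected. For compound 3 the estimated value is 12000 nM, with an expected range of 4000 nM to 30000 nM.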

Compound 3, concentration for 50% growth inhibition: 8290 nM
Compound 3: the middle estimate sits 1.4-fold (0.16 log units) above what was measured; the measured number falls inside the stated range.
By their numbers in this assay, from the lowest: compounds 3, 1 and 2 (each within the scatter of the next, the first and the last beyond it).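

With 3-nitrophenyl in place of 4-methylphenyl, the step is a 1.2-fold lower number from compound 1 to compound 3 (0.09 log units; within the scatter), so a nitro-bearing ring is tolerated at this carbon with a double bond to nitrogen and the number stays level. Within the data shown here, with 3-nitrophenyl in place of 4-(dimethylamino)phenyl, the step is a 2.4-fold lower number from compound 2 to compound 3 (0.37 log units; beyond the scatter), the only step so far beyond the scatter, and it is modest. No evidence on the cause of either step is at hand.

Going by these compounds, what a carboxylic acid, a primary amine or a chlorine on this ring would give stays open. So does the effect of any change elsewhere in the shared core.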